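Moving a methyl group: from compound 2 to compound 3

The source may report more compounds than this note shows. Statements on the series, on what has been measured and on what is new or still open speak of the compounds shown alone.

Within the data shown here, in an ADME assay on the whole organism (plasma, Rattus norvegicus, strain Sprague-Dawley) for pharmacokinetics, read by LC-MS, using cassette dosing, at a dose of 0.2 mg/kg by the intravenous route (a higher number here means more compound in the circulation at the dose given, a lower number less compound in the circulation), compound 2 `CNCc1cn(S(=O)(=O)c2cccnc2C)c(-c2cccnc2F)c1F` gives 32 ng.h/mL and this is the only number so far. Among the measured compounds shown here, for compound 1 `CNCc1cn(S(=O)(=O)c2cncc(Cl)c2)c(-c2cccnc2F)c1F` the entry reads "not determined" (no result reported) and so no measured step exists to lean on. Compound 3 `CNCc1cn(S(=O)(=O)c2ccc(C)nc2)c(-c2cccnc2F)c1F` has the same atoms joined differently, with 6-methylpyridin-3-yl in place of 2-methylpyridin-3-yl on a sulfonyl sulfur as the whole change. With one number to go on, no step beyond the usual scatter is expected in this assay in either direction. The estimated change is a 1.3-fold higher number from compound 2 to compound 3 (0.10 log units; within the scatter) on this reading. For compound 3 the expected value is 40 ng.h/mL within an estimated range from 15 ng.h/mL to 110 ng.h/mL for now.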

Compound 3, area under the concentration-time curve: 41 ng.h/mL
Compound 3: the middle estimate sits 1.0-fold (0.01 log units) below what was measured, and the stated range covers the measured number.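

Among these compounds, this is the first measured comparison at the group on the sulfonyl sulfur: in this assay, 6-methylpyridin-3-yl in place of 2-methylpyridin-3-yl gives a 1.3-fold higher number from compound 2 to compound 3 (0.11 log units; within the scatter). The two placements of the methyl group therefore cannot be told apart in this read-out, at least for this pair of compounds. Nothing measured here bears on this result. As far as these compounds go, it remains open whether a different group on this pyridine ring, such as an amine or a carboxylic acid, would move the number beyond the scatter. The same question holds for a plain phenyl ring in place of the pyridine.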